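This account rests on a few compounds, and the source may have more. Where it says the series, first, only, none or still open, it means among the compounds named here.

Measured in an ADME assay on HeLa cells (Homo sapiens) for cytotoxicity, read by crystal violet staining, with a stated time of 72 h; on this read-out lower numbers stand for higher toxicity in this test and higher numbers for lower toxicity in this test:
- compound 1 `CCOC(=O)c1cc(CCCOc2ccc(-c3noc(C(F)(F)F)n3)cc2C)on1`: 35100 nM
- compound 2 `CCOC(=O)c1cc(CCCOc2ccc(-c3noc(C(F)(F)F)n3)cc2F)on1`: 60200 nM
- compound 3 `CCOC(=O)c1cc(CCCOc2ccc(-c3noc(C(F)(F)F)n3)cc2C(F)(F)F)on1`: 28400 nM

Compound 3 cannot be told apart from compound 1, as the record shows a 1.2-fold lower number from compound 1 to compound 3 (0.09 log units; within the scatter). It does stand apart from compound 2, with a 2.1-fold lower number from compound 2 to compound 3 (0.33 log units; beyond the scatter). The remaining step is a 1.7-fold higher number from compound 1 to compound 2 (0.23 log units; within the scatter).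

Compound 4 `CCOC(=O)c1cc(CCCOc2ccc(-c3noc(C(F)(F)F)n3)cc2/N=C/N(C)C)on1` changes the same aromatic carbon: a group of 5 heavy atoms (3 carbon, 2 nitrogen; no ring) in place of a group of 4 heavy atoms (1 carbon, 3 fluorine; no ring), on an aromatic carbon. Among the measured compounds shown here, no measured compound carries a group of this kind, so the three swaps offer only a rough guide. All of them are small, so a small step is expected in this assay, with no firm direction and probably within the scatter. The expected step is a 1.2-fold higher number from compound 3 to compound 4 (0.09 log units; within the scatter). For compound 4 the estimated value is 35000 nM, with an expected range of 14000 nM to 80000 nM.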

Compound 4, half-maximal cytotoxic concentration: > 100000 nM
Compound 4 ended at the assay's limit (the forecaster's own chance of this, stated with the estimate: 10%); middle value at least 2.8-fold (0.45 log units) from the limit.
By their numbers in this assay, from the lowest: compounds 3, 1 and 2 (each within the scatter of the next, the first and the last beyond it). At a limit, above all of these: compound 4.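

In this assay compound 4 stands at a limit of the test, not at a measured number: the limit of > 100000 nM in this assay, at which 1 of the 4 values shown sits. The earlier swaps at this aromatic carbon gave modest steps at most, whereas this group of 5 heavy atoms gives an at least 3.5-fold higher number from compound 3 to compound 4 (0.54 log units; beyond the scatter) and an at least 2.8-fold higher number from compound 1 to compound 4 (0.45 log units; beyond the scatter). Against the fluoro compound the step is less settled, at an at least 1.6-fold higher number from compound 2 to compound 4 (0.22 log units; that floor lies within the scatter).

The compounds shown leave open how far the value of compound 4 lies past the limit. They also leave open whether a plain amine or an amide on this carbon would give a similar result.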